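A fluorine shift on a weakly active core

The compounds below may be only part of what the source reports. "The series", "measured", "known", "first", "only" and "open" are said of these compounds alone.

Of the compounds shown here, three on one shared core have been tested in a functional assay on K562 cells (Homo sapiens) for cytotoxicity, read by CCK-8 assay, with a stated time of 72 h; a lower number here means a stronger inhibitor, a higher number a weaker inhibitor. Compound 1 `C=CCn1c(=O)/c(=C\c2cccc(C)c2)[nH]c(=O)/c1=C\c1ccccc1OC` gives 8800 nM. Compound 2 `C=CCn1c(=O)/c(=C\c2ccc(Cl)c(Cl)c2)[nH]c(=O)/c1=C\c1ccccc1` is reported as "not active" (no number reported). Compound 3 `C=CCn1c(=O)/c(=C\c2ccc(F)c(Br)c2)[nH]c(=O)/c1=C\c1ccccc1OC` is likewise reported as "not active" (no number reported), so no single number marks where it stands; among the measured compounds only compound 1 gives a number at all. Compound 4 `C=CCn1c(=O)/c(=C\c2ccccc2F)[nH]c(=O)/c1=C\c1ccccc1OC` differs from compound 3 by 2-fluorophenyl in place of 3-bromo-4-fluorophenyl on a double-bonded chain carbon bound to an aromatic carbon. Among the compounds with values here, no measured pair shows what such a change does, so no size or direction of step can be drawn from the data. The outcome for compound 4 is expected to be weak, close to compound 1 or again without a number, estimated at 15000 nM within 5000 nM to 60000 nM.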

Compound 4, half-maximal inhibitory concentration: 5600 nM
Estimate against measurement, compound 4: 2.7-fold (0.43 log units) above; the range from low to high includes it.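

In this assay compound 3 is reported as not active, whereas compound 4, with 2-fluorophenyl in place of 3-bromo-4-fluorophenyl, gives 5600 nM as a measurable result. The change from 3-methylphenyl to 2-fluorophenyl gives a 1.6-fold lower number from compound 1 to compound 4 (0.20 log units; within the scatter) and so does not separate these two groups. Nothing available explains these results. Going by these compounds, it remains open whether the bromine, the fluorine or both go with the missing number in compound 3. Also open, on these data alone, is how a phenyl group carrying an amine or a carboxylic acid would behave here.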